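Moving Two Methyl Groups on a Phenyl Ring

The source may report more compounds than this note shows. Statements on the series, on what has been measured and on what is new or still open speak of the compounds shown alone.

In an ADME assay (liver) for metabolic stability, with Liver microsome (Homo sapiens) as the target, read by LC-MS, using microsomes, with a stated time of 1 h, tested at 5 uM (on this read-out higher numbers stand for a more stable compound and lower numbers for a less stable compound), compound 1 (`Cc1nc(-c2ccccc2)c(C(=O)N2CCN(c3cccc(C)c3C)CC2)o1`) gives 29.8%, the lowest of the three numbers measured. Compound 3 (`CCC[C@H](Nc1nc(-c2ccc(NC(=O)NCC)c(OC)c2)ncc1C)c1cccnc1`) gives 54.6% and compound 2 (`Cc1nc(-c2ccc(F)cc2)c(C(=O)N2CCN(c3cc(Cl)cc(Cl)c3)CC2)o1`) gives 71.8%, and both lie beyond the scatter above compound 1. Compound 4 (`Cc1cc(C)cc(N2CCN(C(=O)c3oc(C)nc3-c3ccccc3)CC2)c1`) has not yet been measured in this assay. It carries 3,5-dimethylphenyl in place of 2,3-dimethylphenyl on an amine nitrogen in a ring, and the two compounds have the same atoms, joined differently: 3,5-dimethylphenyl in place of 2,3-dimethylphenyl on an amine nitrogen in a ring. Within the data shown here, no measured pair differs in one place only, so the data offer no direct precedent for this change. The best anchor is therefore compound 1 with its 29.8%, and no change beyond the scatter is expected. The expected step is a number 3.2 percentage points higher from compound 1 to compound 4 (within the scatter), a small upward move at most. For compound 4, the estimated value is 33%, with an expected range from 15% to 52%.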

Compound 4, percent of the compound remaining: 25.6%
For compound 4 the middle estimate is 7.4 percentage points above the measured one; the measured number falls inside the stated range.
By their numbers in this assay, from the lowest: compounds 4 and 1 (each within the scatter of the next); then compound 3; then compound 2.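

Among these compounds, this is the first pair in the set that differs in one place only, and it isolates the placement of the two methyl groups on the phenyl ring. In this assay, 3,5-dimethylphenyl in place of 2,3-dimethylphenyl on the amine nitrogen in the ring gives a number 4.2 percentage points lower from compound 1 to compound 4 (within the scatter), so the two compounds cannot be told apart on this read-out and the arrangement of these two methyl groups has no resolved effect here. No measurement in hand explains this result.

Compound 2 differs from both compounds in more than one place, so it cannot show what a single substitution on this phenyl ring would do. Going by these compounds, it remains open whether a different group at this position, such as a methoxy group, an amine or a carboxylic acid, would move the number beyond the scatter.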